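Lengthening the Chain From Compound 3 to Compound 4

The compounds below may be only part of what the source reports. "The series", "measured", "known", "first", "only" and "open" are said of these compounds alone.

For the measured compounds named here, compound 3 `CSc1nc(NCCCc2ccccc2)c2ccccc2n1` is the only one of three compounds that gives a number in a functional assay on CCRF-CEM cells (Homo sapiens) for cytotoxicity, read by MTT assay, with a stated time of 72 h (a higher number here means a weaker inhibitor of growth, a lower number a stronger inhibitor of growth), where compound 3 reaches 87800 nM. Compound 1 `COc1ccc(CNc2nc(SC)nc3ncccc23)cc1` gives > 100000 nM, a limit of the assay rather than a number. Compound 2 `CSc1nc(NCCCCCO)c2ccccc2n1` gives > 100000 nM, again a limit. Going by the values given here, the only measured step, an at least 1.1-fold lower number from compound 2 to compound 3 (0.05 log units; that floor lies within the scatter), starts from that limit (the limit of > 100000 nM in this assay, at which 2 of the 3 values shown sit). Compound 4 `CSc1nc(NCCCCc2ccccc2)c2ccccc2n1` differs from compound 3 by benzyl in place of phenyl on a saturated chain carbon, three bonds along the chain from a nitrogen on an aromatic ring. Among the compounds with values here, no measured step tests such a change; the step from compound 2 to compound 3 shows only that a phenyl-bearing chain reaches the measurable range. A step of a 1.1-fold lower number from compound 3 to compound 4 (0.04 log units; within the scatter) is therefore expected, within the scatter. Compound 4 is estimated at 80000 nM, between 35000 nM and 200000 nM.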

Compound 4, concentration for total growth inhibition: > 100000 nM
Compound 4 gave a limit, no number; the forecaster's own chance of this, stated with the estimate: 35%; middle value at least 1.2-fold (0.09 log units) away from the limit.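

On this saturated chain carbon, benzyl in place of phenyl gives an at least 1.1-fold higher number from compound 3 to compound 4 (0.05 log units; that floor lies within the scatter) in this assay and, with compound 4 at a limit, only that floor can be read. As far as these compounds go, the longer phenyl-bearing chain of compound 4 therefore does not stay in the measurable range reached by compound 3, and the true size of the change remains unknown: the limit of > 100000 nM in this assay, at which 3 of the 4 values shown sit. The step from compound 2 to compound 4 cannot be read.

From the compounds shown here alone, whether a shorter chain, or an amine in place of the phenyl, would give a lower number in this assay stays open.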